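A few compounds are considered here, and "the series" means these few. Any claim that something is new, unique, unknown or untested is made for them only; others in the source may bear on it.

Of the compounds shown here, three have been measured so far in a functional assay on HT-1080 cells (Homo sapiens) for cytotoxicity, read by MTT assay, with a stated time of 72 h; on this read-out lower numbers stand for stronger inhibition and higher numbers for weaker inhibition. Compound 1 `N=C(Nc1cccc(C(F)(F)F)c1)c1cc2c(-c3ccccc3)n[nH]c2cn1` gives 24600 nM, compound 2 `N=C(Nc1ccccc1)c1cc2c(-c3ccccc3)n[nH]c2c(NC2CCCCC2)n1` gives 850 nM, and compound 3 `COc1ccc(Cn2nc(-c3ccccc3)c3cc(C(=N)Nc4ccccc4)ncc32)cc1` gives 4700 nM. Among these three numbers compound 3 stands second highest: its nearest neighbour is compound 1, whose number is higher by more than the usual scatter, and its furthest is compound 2, whose number is lower by more than the usual scatter.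

Compound 4 `N=C(Nc1ccccc1)c1cc2c(-c3ccccc3)n[nH]c2cn1` is not yet measured. It differs from compound 3 in one place: hydrogen in place of 4-methoxybenzyl on an aromatic nitrogen. Going by the values given here, no measured pair shows this exact change, so its effect has to be inferred from the spread of the three numbers in this assay. Compound 1 and compound 2 both carry the hydrogen at this aromatic nitrogen, and their numbers lie on either side of compound 3, so the change alone does not point firmly in one direction. For compound 4 a modest shift toward a higher number is expected, a 1.7-fold higher number from compound 3 to compound 4 (0.23 log units; within the scatter), with the estimate for compound 4 placed at 8000 nM and a range from 2000 nM to 30000 nM.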

Compound 4, half-maximal inhibitory concentration: 22000 nM
For compound 4 the middle estimate is 2.8-fold (0.44 log units) below the measured one; measured number inside the range.
By their numbers in this assay, from the lowest: compound 2; then compound 3; then compounds 4 and 1 (each within the scatter of the next).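

In this assay, replacing 4-methoxybenzyl on the aromatic nitrogen with hydrogen gives a 4.7-fold higher number from compound 3 to compound 4 (0.67 log units; beyond the scatter), so the group on this nitrogen matters and the compound carrying it has the lower number. Two other changes on the same frame put this in context: hydrogen in place of cyclohexylamino on an aromatic carbon is a large step, a 26-fold higher number from compound 2 to compound 4 (1.41 log units; beyond the scatter), while hydrogen in place of trifluoromethyl on an aromatic carbon gives a 1.1-fold lower number from compound 1 to compound 4 (0.05 log units; within the scatter), which lies within the scatter. Nothing available gives a reason for any of these steps.

From the compounds shown here alone, it remains open whether a plain benzyl or a methyl on that nitrogen would lower the number as 4-methoxybenzyl does. Going by these compounds, it is also open whether a smaller amine, such as methylamino, could stand in for cyclohexylamino on its aromatic carbon.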